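The source may hold more compounds than are shown below. What is called first, only, known or untested is meant among the compounds shown, and "the series" means these compounds.

Compound 1 `O=C(CCc1ccc2[nH]c(-c3ccc(Cl)s3)nc2c1)Nc1ccc(N2CCOCC2=O)cc1` has been examined in an in vivo ADME assay on the whole organism for pharmacokinetics, with Rattus norvegicus as the target; on this read-out higher numbers stand for higher oral bioavailability and lower numbers for lower oral bioavailability. In this assay compound 1 gives < 20%, which is a limit of the assay. Compound 2 `O=C(CCc1ccc2[nH]c(-c3ccc(Cl)s3)nc2c1)Nc1ccc(-n2ccccc2=O)c(F)c1` likewise returns < 20% in this assay, again a limit. Compound 3 `O=C(CNC(=O)Nc1ccc(Cl)cc1)Nc1ccc(N2CCOCC2=O)cc1`, built on a different core, gives < 20% in this assay, also a limit. The evidence so far therefore amounts to the limit of < 20% in this assay, at which 3 of the 3 values shown sit. Compound 4 `Cc1cc(NC(=O)CCc2ccc3[nH]c(-c4ccc(Cl)s4)nc3c2)ccc1N1CCOCC1=O` has not yet been measured in this assay; it differs from compound 1 by methyl in place of hydrogen on an aromatic carbon. Among the measured compounds shown here, no pair of measured compounds provides a step to lean on, so the step that the limit leaves unreadable from compound 1 to compound 4 is expected to remain within the usual scatter, in no clear direction. Compound 4 is estimated to reach 12%, with a range from 3% to 30%.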

Compound 4, oral bioavailability: < 20%
Compound 4: no number, only a limit (the forecaster's own chance of this, stated with the estimate: 70%); the middle value lies beyond the limit too.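

Among the compounds shown here, compound 1 and compound 4 both sit at a limit, so no step between them can be read in this assay. The compounds shown leave open whether methyl in place of hydrogen on an aromatic carbon changes this read-out at all.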